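The source may hold more compounds than are shown below. What is called first, only, known or untested is meant among the compounds shown, and "the series" means these compounds.

Measured so far:
compound 1 `CNC(=O)c1cc(C(=O)NC2CC2)cn(Cc2cccc(F)c2)c1=O` — >= 133 ug/mL
compound 2 `CNC(=O)c1cc(C(=O)NCC(C)C)cn(Cc2ccccc2)c1=O` — 43 ug/mL

In a physicochemical assay for solubility (on this read-out higher numbers stand for higher solubility and lower numbers for lower solubility), compound 1 gives only a limit, >= 133 ug/mL, so its true position is not fixed by a number. In this assay compound 2 gives 43 ug/mL. What holds for compound 1 on this read-out is the limit of >= 133 ug/mL in this assay, at which 1 of the 2 values shown sits. Compound 3 `CNC(=O)c1cc(C(=O)NC2CC2)cn(Cc2cccc3occc23)c1=O` has not yet been run in this assay. It differs from compound 1 by 1-benzofuran-4-yl in place of 3-fluorophenyl on a saturated chain carbon bound to an aromatic nitrogen. Because compound 1 sits at a limit, any step from it can be bounded from one side only. The expectation in this assay is a downward move beyond the usual scatter, with compound 3 expected to fall short of the limit seen for compound 1 and to sit closer to where compound 2 lies. The estimated step is an at least 3.3-fold lower number from compound 1 to compound 3 (0.52 log units; beyond the scatter). Compound 3 is expected to give 40 ug/mL, within a range of 10 ug/mL to 130 ug/mL.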

Compound 3, solubility: >= 110 ug/mL
Compound 3: a limit, no number; the forecaster's own chance of this, stated with the estimate: 20%; middle value at least 2.7-fold (0.43 log units) away from the limit.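

In this assay compound 1 gives a limit, >= 133 ug/mL. Compound 3 also gives a limit, >= 110 ug/mL. No step can be read between compound 1 and compound 3. Still open, as far as these compounds go, is how far 1-benzofuran-4-yl in place of 3-fluorophenyl moves the read-out, if at all.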